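The source may hold more compounds than are shown below. What is called first, only, known or untested is meant among the compounds shown, and "the series" means these compounds.

Measured compounds:
- compound 1 `O=C(C1CC1)N1CCN(Cc2nc3ccccc3n2Cc2ccccc2)CC1`: 23.9%
- compound 2 `O=C(C1CC1)N1CCN(Cc2nc3ccccc3n2Cc2ccc(C(F)(F)F)cc2)CC1`: 37%

Both compounds share one core and differ only in the substituent on the aromatic ring attached to the chain carbon bound to the aromatic nitrogen. In an assay on isolated protein for inhibition of aldehyde dehydrogenase 1A1 (Homo sapiens), read by spectrophotometry, tested at 10 uM (on this read-out higher numbers stand for more inhibition at the one concentration tested (going by the name of the read-out) and lower numbers for less inhibition), compound 1 gives 23.9%, and compound 2 gives 37%. Within the data shown here, the single step available, a number 13.1 percentage points higher from compound 1 to compound 2 (beyond the scatter), places compound 2 highest of the two numbers, with compound 1 as its nearest neighbour, a step beyond the scatter.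

Compound 3 `CCCCn1c(CN2CCN(C(=O)C3CC3)CC2)nc2ccccc21` is the next compound to be measured. Relative to compound 2 the change is propyl in place of 4-(trifluoromethyl)phenyl on a saturated chain carbon bound to an aromatic nitrogen. Among the measured compounds shown here, no measured step covers the loss of the aromatic ring itself; the one step on record, from compound 1 to compound 2, only shows that the trifluoromethyl-bearing ring gives a modestly higher number than the unsubstituted ring. Removing that ring in favour of propyl is therefore an untested direction. Compound 3 is expected to lose the gain seen with compound 2 and fall at or below compound 1, so a downward step of about a number 17 percentage points lower from compound 2 to compound 3 (beyond the scatter) is estimated, with wide uncertainty. The estimate for compound 3 in this assay is 20%, within 5% to 38%.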

Compound 3, a percentage reported as inhibition, at one concentration (the size of the read-out at that concentration, not a potency): 18.2%
Compound 3: middle estimate off by 1.8 percentage points, on the high side; low and high end bracket the measured number.
By their numbers in this assay, from the lowest: compounds 3 and 1 (each within the scatter of the next); then compound 2.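

In this assay the step of a number 5.7 percentage points lower from compound 1 to compound 3 (within the scatter) shows that propyl and phenyl cannot be told apart on a saturated chain carbon bound to an aromatic nitrogen, so an unsubstituted aromatic ring in this place brings no measurable gain over a short open chain. The step of a number 18.8 percentage points lower from compound 2 to compound 3 (beyond the scatter) sets the higher number of compound 2 apart from both other compounds, which ties it, within these three compounds, to the 4-(trifluoromethyl)phenyl group as a whole and not to the presence of an aromatic ring alone. Nothing on hand gives a reason for either step.

Open, going by these compounds, is whether a longer chain such as hexyl, or a chain ending in a carboxylic acid or an amine, would read differently from propyl in this place. Also open, on these data alone, is whether a chlorine or a methoxy group on the phenyl ring would reach the level of compound 2 or whether trifluoromethyl stands alone in giving a number beyond the scatter of the phenyl and propyl compounds.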